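Lengthening the Linker by One Carbon: What to Expect

A few compounds are considered here, and "the series" means these few. Any claim that something is new, unique, unknown or untested is made for them only; others in the source may bear on it.

Compound 1, `CCC(=O)c1ccc2c(c1)sc(=O)n2CCCCN1CCCCCC1`, gives 10.3 nM in an assay on cell membranes for displacement of a labelled ligand from Sigma non-opioid intracellular receptor 1 (Rattus norvegicus); on this read-out lower numbers stand for stronger inhibition and higher numbers for weaker inhibition. Compound 2, `CCC(=O)c1ccc2c(c1)sc(=O)n2CCCCCN1CCCCCC1`, gives 12.2 nM. Compound 3, `CCCc1ccc2c(c1)sc(=O)n2CCCN1CCCCCC1`, gives 1.4 nM.

Compounds 1 and 2 share a core and differ only in one place: (azepan-1-yl)methyl in place of azepan-1-yl on a saturated chain carbon, four bonds along the chain from an aromatic nitrogen. That change produced a 1.2-fold higher number from compound 1 to compound 2 (0.07 log units; within the scatter), so the two numbers cannot be told apart on this read-out. Compound 3 carries a different core; how it differs from the core of compound 1 is not broken down here, and the two values simply show that compound 3 stands at the lowest number of the three, beyond the scatter from both compound 1 and compound 2.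

The unmeasured compound 4, `CCCc1ccc2c(c1)sc(=O)n2CCCCN1CCCCCC1`, relates to compound 3 in the following way: (azepan-1-yl)methyl in place of azepan-1-yl on a saturated chain carbon, three bonds along the chain from an aromatic nitrogen. Within the data shown here, this is the same kind of change as the one from compound 1 to compound 2, though not the same: there the new group sat four bonds along the chain from the aromatic nitrogen, here it sits three bonds along. Among the measured compounds shown here, the only precedent is therefore the pair of compounds 1 and 2, where the step stayed within the scatter.

Resting on that single precedent, compound 4 is expected to show a 1.3-fold higher number from compound 3 to compound 4 (0.11 log units; within the scatter), a step of about the size seen from compound 1 to compound 2. Compound 4 is accordingly estimated at 1.8 nM, with a likely range from 0.7 nM to 4.5 nM, the width reflecting that the chain position differs from the measured precedent.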

Compound 4, inhibition constant: 6.1 nM
Compound 4: middle estimate off by 3.4-fold (0.53 log units), on the low side; measured number above the stated range.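

On the core of compound 3 the change gave a 4.4-fold higher number from compound 3 to compound 4 (0.64 log units; beyond the scatter) in this assay and so did not repeat the step seen on the core of compound 1: the same change on two cores in this assay, a 1.2-fold higher number (0.07 log units; within the scatter) from compound 1 to compound 2 and a 4.4-fold higher number (0.64 log units; beyond the scatter) from compound 3 to compound 4, 3.7-fold (0.57 log units) apart, beyond the scatter of two such steps. The change therefore does not carry over at one fixed size between these two cores, and a step within the scatter on one core says little about its size on the other. The pair does not show whether the gap goes with the propyl or propanoyl group on the aromatic carbon or with the chain position, three bonds along in one case and four in the other, and the remaining comparison gives a 1.7-fold lower number from compound 1 to compound 4 (0.23 log units; within the scatter) and so leaves those two compounds indistinguishable on this read-out.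

Still open, on these data alone, is how a core carrying propanoyl responds when the same change is made three bonds along the chain from the aromatic nitrogen, which would separate the two differences. Also open, as far as these compounds go, is whether a longer chain on either core, or a piperidine in place of the azepane ring, would follow the pattern of compound 1 to compound 2 or that of compound 3 to compound 4.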